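The source may hold more compounds than are shown below. What is called first, only, known or untested is meant among the compounds shown, and "the series" means these compounds.

Measured so far in an in vitro functional assay on cells (Fibroblast) for agonist activity at Alpha-1D adrenergic receptor (Homo sapiens); on this read-out higher numbers stand for an effect only at larger amounts of compound and lower numbers for an effect already at smaller amounts:
- compound 1 `c1ccc(-c2nc[nH]n2)c(NCC2=NCCN2)c1`: 3.98 nM
- compound 2 `CC(C)n1ncnc1-c1ccccc1NCC1=NCCN1`: 3160 nM
- compound 3 `Cc1nc(-c2ccccc2NCC2=NCCN2)n(C)n1`: < 5020 nM

Compound 1 stands lowest of the two numbers; compound 2 sits a long way higher, well beyond the scatter. For compound 3 the value is a limit of this assay, not a number (the limit of < 5020 nM in this assay, at which 1 of the 3 values shown sits). Compound 4 `Cn1ccc(-c2ccccc2NCC2=NCCN2)n1` is not yet measured. It differs from compound 1 as 1-methyl-1H-pyrazol-3-yl in place of 1H-1,2,4-triazol-3-yl on an aromatic carbon; the hydrogen-bond donor of the ring is gone and a methyl sits on ring nitrogen. Compounds 2 and 3, which carry substituents on the ring and lack the ring hydrogen-bond donor of compound 1, both give far higher numbers, so a sizeable loss is expected from compound 1 to compound 4 a 160-fold higher number from compound 1 to compound 4 (2.20 log units; beyond the scatter). Compound 4 is therefore estimated at 630 nM, expected between 63 nM and 6300 nM.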

Compound 4, half-maximal effective concentration: 15.9 nM
For compound 4 the middle estimate is 40-fold (1.60 log units) above the measured one, and the stated range ends above it.
By their numbers in this assay, from the lowest: compound 1; then compound 4; then compound 2.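

At this position on the aromatic carbon, 1-methyl-1H-pyrazol-3-yl replaces 1H-1,2,4-triazol-3-yl in this assay with only a modest cost: a 4.0-fold higher number from compound 1 to compound 4 (0.60 log units; beyond the scatter). A ring with 0 hydrogen-bond donors can therefore still give a low number in this series. Nothing shown gives a cause for this step.

On these data alone, the step changes the ring and adds the methyl together, so the share of each remains open. Also open, as far as these compounds go, is how an unmethylated 1H-pyrazol-3-yl, or an ethyl or a primary amine on the pyrazole, would read out here.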